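The compounds below may be only part of what the source reports. "The series", "measured", "known", "first", "only" and "open" are said of these compounds alone.

Compound 2 `CCCCC(=O)Nc1cc(Oc2ccc(Nc3nccc4[nH]cc(-c5ccc(F)cc5)c(=O)c34)cc2F)ccn1` stands lowest of the three numbers in a functional assay on HT-29 cells (Homo sapiens) for antiproliferative activity, read by MTT assay, with a stated time of 72 h, tested at 10 uM (on this read-out lower numbers stand for less inhibition and higher numbers for more inhibition at the one concentration tested (going by the name of the read-out)), where compound 2 gives -42.2%; compound 3 `CC(C)(O)C(=O)Nc1cc(Oc2ccc(Nc3nccc4[nH]cc(-c5ccc(F)cc5)c(=O)c34)cc2F)ccn1` gives -2.9%, and compound 1 `Cn1cc(-c2ccc(F)cc2)c(=O)c2c(Nc3ccc(Oc4ccnc(NC(=O)C5CC5)c4)c(F)c3)nccc21` gives 24.8%. Compound 4 `CC(C)(C)C(=O)Nc1cc(Oc2ccc(Nc3nccc4[nH]cc(-c5ccc(F)cc5)c(=O)c34)cc2F)ccn1` differs from compound 2 by tert-butyl in place of butyl on a carbonyl carbon. Among the measured compounds shown here, the one measured step that bears on this change is a number 39.3 percentage points higher from compound 2 to compound 3 (beyond the scatter), which likewise removes the butyl from the carbonyl carbon, though the group entering there is 1-hydroxy-1-methylethyl rather than tert-butyl. Compound 1 differs from compound 2 in more than one place, so its value only shows how far the series reaches in this assay. An upward step of smaller size is therefore expected, a number 27.2 percentage points higher from compound 2 to compound 4 (beyond the scatter). Compound 4 is estimated at -15%, in a range from -45% to 15%.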

Compound 4, a percentage reported as inhibition, at one concentration (the size of the read-out at that concentration, not a potency): -45.8%
The estimate for compound 4 lay 30.8 percentage points above the measured number; the measured number lies below the stated range.
By their numbers in this assay, from the lowest: compounds 4 and 2 (each within the scatter of the next); then compound 3; then compound 1.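

In this assay, tert-butyl in place of butyl on the carbonyl carbon gives a number 3.6 percentage points lower from compound 2 to compound 4 (within the scatter), so these two chains cannot be told apart at this position. Methyl in place of hydroxy on the saturated chain carbon gives a number 42.9 percentage points lower from compound 3 to compound 4 (beyond the scatter), which ties the higher number of compound 3 to the hydroxy and not to the branched carbon skeleton it shares with compound 4. Nothing available explains this difference.

Going by these compounds, it remains open whether an amine or a carboxylic acid in place of that hydroxy would go with a similar number. On these data alone, it is also open whether a hydroxy on a longer chain would do so.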